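Imidazole to Triazole on a Salicylic Acid Scaffold

A few compounds are considered here, and "the series" means these few. Any claim that something is new, unique, unknown or untested is made for them only; others in the source may bear on it.

Measured so far:
compound 1 `O=C(O)c1cc(-n2ccnc2)ccc1O` — 75 mg/kg
compound 2 `O=C(O)c1cc(-c2ccccn2)ccc1O` — 200 mg/kg

In a functional assay on the whole organism for inhibition, with Rattus norvegicus as the target, read by paw edema (a lower number here means that less compound is needed, a higher number that more compound is needed for the effect), compound 1 gives 75 mg/kg, the lowest of the two numbers shown. In this assay compound 2 gives 200 mg/kg, a higher number that lies beyond the scatter of the method. Going by the values given here, no step between the measured compounds is available, so compound 2 informs only by comparison. Compound 3 `O=C(O)c1cc(-n2cnnc2)ccc1O` is not yet measured; it differs from compound 1 by 4H-1,2,4-triazol-4-yl in place of 1H-imidazol-1-yl on an aromatic carbon. A small step is expected in this assay, none beyond the scatter, which gives a 1.2-fold higher number from compound 1 to compound 3 (0.08 log units; within the scatter). For compound 3 the estimate in this assay is 90 mg/kg, with a range from 40 mg/kg to 200 mg/kg.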

Compound 3, dose for half-maximal effect: > 250 mg/kg
Compound 3 gave a limit, no number (the forecaster's own chance of this, stated with the estimate: 10%); middle value at least 2.7-fold (0.44 log units) from the limit.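

In this assay compound 3 gives > 250 mg/kg, a limit of the assay and not a number. Even so, the change can be read as an at least 3.3-fold higher number from compound 1 to compound 3 (0.52 log units; beyond the scatter), which shows that this position, para to the hydroxy group, is sensitive to a ring nitrogen even though both five-membered rings have 5 heavy atoms. The reading rests on a limit: the limit of > 250 mg/kg in this assay, at which 1 of the 3 values shown sits.

On these data alone, the true size of the step remains open. As far as these compounds go, it is also open how a 1H-pyrazol-1-yl ring or an amine at this position would fare in this assay.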